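Swapping the cyclobutylamide for a dimethylmorpholine amide

A few compounds are considered here, and "the series" means these few. Any claim that something is new, unique, unknown or untested is made for them only; others in the source may bear on it.

Measured so far:
compound 1 `O=C(CCc1ccc(NC(=O)Nc2ccc(Cl)c(C(F)(F)F)c2)cc1)NC1CCC1`, > 50000 nM
compound 2 `CNC(=O)/C=C/c1ccc(NC(=O)Nc2ccc(Cl)c(C(F)(F)F)c2)cc1`, 21200 nM
compound 3 `CNC(=O)c1cccc(-c2ccc(NC(=O)Nc3ccc(Cl)c(C(F)(F)F)c3)cc2)c1`, 39300 nM

All three compounds share the same core and were tested in a functional assay on KETR3 cells (Homo sapiens) for inhibition, read by MTT assay, with a stated time of 120 h; a lower number here means a stronger inhibitor, a higher number a weaker inhibitor. Compound 1 gives only a limit there, > 50000 nM, so its true value is not known, only that it sits beyond the edge of what the assay reports (the limit of > 50000 nM in this assay, at which 1 of the 3 values shown sits). Compound 2 gives 21200 nM and compound 3 gives 39300 nM; the step of an at least 2.3-fold lower number from compound 1 to compound 2 (0.37 log units; beyond the scatter) is the only one of the three that clears the scatter, while an at least 1.2-fold lower number from compound 1 to compound 3 (0.10 log units; that floor lies within the scatter) and a 1.9-fold higher number from compound 2 to compound 3 (0.27 log units; within the scatter) do not. So within this series every compound is a weak inhibitor.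

Compound 4 `CC1CN(C(=O)CCc2ccc(NC(=O)Nc3ccc(Cl)c(C(F)(F)F)c3)cc2)CC(C)O1` differs from compound 1 in one place: 2,6-dimethylmorpholin-4-yl in place of cyclobutylamino on a carbonyl carbon. Among the measured compounds shown here, none of the measured steps touches this part of the molecule; they alter the group on the aromatic carbon instead, and they all leave the compounds weak. For the measured compounds named here, with no step to lean on, the expectation is simply that compound 4 stays near compound 1, with a step of a number no higher from compound 1 to compound 4 (the limit leaves the size open). Compound 4 is therefore estimated at 50000 nM, expected to lie between 20000 nM and 120000 nM, and may well come back as a limit again.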

Compound 4, half-maximal inhibitory concentration: > 50000 nM
Compound 4: a limit, no number (the forecaster's own chance of this, stated with the estimate: 60%); the middle value sits exactly at the limit.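

Compound 1 and compound 4 both return only a limit rather than a number, so no step between them can be read: the limit of > 50000 nM in this assay, at which 2 of the 4 values shown sit.

The compounds shown leave open how strongly either compound inhibits, and whether 2,6-dimethylmorpholin-4-yl in place of cyclobutylamino on a carbonyl carbon makes any difference to that.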